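Methyl additions in a kinase inhibitor series

The source may report more compounds than this note shows. Statements on the series, on what has been measured and on what is new or still open speak of the compounds shown alone.

In an assay on isolated protein for inhibition of Rho-associated protein kinase 1 (Homo sapiens), read by scintillation counting, radiometric assay and 33P incorporation, with a stated time of 40 min, in the presence of a further agent that is not named here (on this read-out higher numbers stand for weaker inhibition and lower numbers for stronger inhibition), compound 1 `O=C(COc1ccc2c(=O)ccoc2c1)Nc1cccc(NC(=O)c2ccccc2)c1` gives 120 nM. Compound 2 `Cc1ccc(C(=O)Nc2cccc(NC(=O)COc3ccc4c(=O)ccoc4c3)c2)cc1` carries methyl in place of hydrogen on an aromatic carbon and gives 183 nM; the step is a 1.5-fold higher number from compound 1 to compound 2 (0.18 log units; within the scatter). Compound 3 `Cc1cc(NC(=O)COc2ccc3c(=O)ccoc3c2)cc(NC(=O)c2ccc(N(C)C)cc2)c1` rests on another core; the difference between the two cores is not broken down here. For compound 3 this assay reports only a limit, > 10000 nM. Compound 4 `Cc1cc(NC(=O)COc2ccc3c(=O)ccoc3c2)cc(NC(=O)c2ccc(N(C)C)cc2)c1C` differs from compound 3 by methyl in place of hydrogen on an aromatic carbon, here ortho to a ((4-(dimethylamino)phenyl)carbonyl)amino group and ortho to a methyl group, whereas the earlier methyl sat only para to a large group, so this is the same kind of change, not the same change. For compound 4 the expected step is a step that the limit leaves unreadable from compound 3 to compound 4, flat like a 1.5-fold higher number from compound 1 to compound 2 (0.18 log units; within the scatter), because compound 3 already sits at the limit of > 10000 nM in this assay, at which 1 of the 3 values shown sits. Compound 4 is therefore expected at 20000 nM, within 5000 nM to 100000 nM, most probably reported again as a limit.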

Compound 4, half-maximal inhibitory concentration: 3950 nM
For compound 4 the middle estimate is 5.1-fold (0.70 log units) above the measured one; measured number outside the range, below it.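

In this assay the new step is an at least 2.5-fold lower number from compound 3 to compound 4 (0.40 log units; beyond the scatter), and it rests on a limit for compound 3, so its full size cannot be read. Set beside the earlier step, the same change does not give the same result on the two cores: the same change on two cores in this assay, a 1.5-fold higher number (0.18 log units; within the scatter) from compound 1 to compound 2 and an at least 2.5-fold lower number (0.40 log units; beyond the scatter) from compound 3 to compound 4, at least 3.8-fold (0.58 log units) apart, beyond the scatter of two such steps. The step seen on one core therefore cannot be assumed on the other, but these data do not separate the effect of the core from that of the methyl's place, which also differs between the two pairs.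

On these data alone, it remains open whether a methyl at the place it holds in compound 4 would give a lower number on the core of compound 1. Also open, as far as these compounds go, is whether an ethyl group or a methoxy group at that place would follow the methyl.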